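Changing the Aryl Group on the Ring Nitrogen

The compounds below may be only part of what the source reports. "The series", "measured", "known", "first", "only" and "open" are said of these compounds alone.

Of the compounds shown here, three sharing a common core have been tested in a functional assay on HepG2 cells (Homo sapiens) for cytotoxicity, read by MTT assay, with a stated time of 72 h; on this read-out lower numbers stand for stronger inhibition and higher numbers for weaker inhibition. Compound 1 `O=C(Nc1ccc(Oc2ccnc3[nH]ccc23)c(F)c1)c1nn(-c2ccc(Cl)c(C(F)(F)F)c2)ccc1=O` gives 11900 nM in this assay. Compound 2 `COc1ccc(-n2ccc(=O)c(C(=O)Nc3ccc(Oc4ccnc5c4ccn5C)c(F)c3)n2)cc1` gives only a limit, > 60000 nM, so no number is known for it. Compound 3 `Cn1ccc2c(Oc3ccc(NC(=O)c4nn(-c5ccc(Br)cc5F)ccc4=O)cc3F)ccnc21` gives 24000 nM in this assay; its number and that of compound 1 lie within the usual scatter of each other, so the two cannot be ranked. Within the data shown here, the one measured step, from compound 2 to compound 3, shows an at least 2.5-fold lower number from compound 2 to compound 3 (0.39 log units; beyond the scatter), with 4-bromo-2-fluorophenyl in place of 4-methoxyphenyl on an aromatic nitrogen; because one end is the limit (the limit of > 60000 nM in this assay, at which 1 of the 3 values shown sits), its true size is not known.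

Compound 4 `Cn1ccc2c(Oc3ccc(NC(=O)c4nn(-c5ccc(Cl)c(C(F)(F)F)c5)ccc4=O)cc3F)ccnc21` differs from compound 3 by 4-chloro-3-(trifluoromethyl)phenyl in place of 4-bromo-2-fluorophenyl on an aromatic nitrogen. Among the measured compounds shown here, compound 1 carries the same 4-chloro-3-(trifluoromethyl)phenyl group as compound 4, but it also differs from compound 3 in a second place, so no single step between them has been measured. For the measured compounds named here, no measured step therefore bears directly on this change. The expected step from compound 3 to compound 4 is a 1.8-fold lower number from compound 3 to compound 4 (0.27 log units; within the scatter), a small move toward the number of compound 1 and within the scatter. Compound 4 is estimated at 13000 nM in this assay, with a likely range from 6000 nM to 30000 nM.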

Compound 4, half-maximal inhibitory concentration: 13500 nM
For compound 4 the middle estimate is 1.0-fold (0.02 log units) below the measured one; the range from low to high includes it.
By their numbers in this assay, from the lowest: compounds 1, 4 and 3 (each within the scatter of the next). At a limit, above all of these: compound 2.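

With the shared core and its methyl on an aromatic nitrogen held the same, 4-chloro-3-(trifluoromethyl)phenyl in place of 4-bromo-2-fluorophenyl gives a 1.8-fold lower number from compound 3 to compound 4 (0.25 log units; within the scatter), so this assay does not separate these two aryl groups at this position, despite the larger group entering. Compounds 1 and 4 carry the same aryl group and differ only in methyl in place of hydrogen on an aromatic nitrogen, and the change gives a 1.1-fold higher number from compound 1 to compound 4 (0.05 log units; within the scatter), so with this aryl group the methyl makes no readable difference. Compound 4 also shows an at least 4.4-fold lower number from compound 2 to compound 4 (0.64 log units; beyond the scatter), which means that two different aryl groups, in compound 3 and compound 4, now stand apart from 4-methoxyphenyl, although the true size of the step stays unknown because compound 2 sits at a limit: the limit of > 60000 nM in this assay, at which 1 of the 4 values shown sits.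

From the compounds shown here alone, whether a plain phenyl group, or an aryl group carrying an amine or a carboxylic acid, would move the number beyond the scatter remains open. Going by these compounds, the methyl comparison also rests on a single aryl group, so it is unknown whether the same holds with 4-bromo-2-fluorophenyl or 4-methoxyphenyl.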